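The compounds below may be only part of what the source reports. "The series", "measured", "known", "first", "only" and "open" are said of these compounds alone.

Of the compounds shown here, three from one series have been tested in a functional assay on VCaP cells (Homo sapiens) for antiproliferative activity, read by propidium iodide staining, with a stated time of 96 h (on this read-out lower numbers stand for stronger inhibition and higher numbers for weaker inhibition), so far, and a fourth awaits its result. Compound 1 `CC(O)(CSc1ccc(C(F)(F)F)cc1)C(=O)Nc1cccc(S(F)(F)(F)(F)F)c1` gives 27300 nM in this assay. Compound 2 `CC(O)(CSc1cccc(C(F)(F)F)c1)C(=O)Nc1cccc(S(F)(F)(F)(F)F)c1` differs from compound 1 by a single change, (3-(trifluoromethyl)phenyl in place of 4-(trifluoromethyl)phenyl on a sulfur), and in this assay compound 2 gives 20200 nM. The step this change made is a 1.4-fold lower number from compound 1 to compound 2 (0.13 log units; within the scatter), so the two values cannot be told apart with confidence.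

Compound 3 `CC(O)(CS(=O)(=O)c1ccc(C(F)(F)F)cc1)C(=O)Nc1ccc(S(F)(F)(F)(F)F)cc1` belongs to the same family but has a different core; how its core differs from that of compound 1 is not broken down here. In this assay compound 3 gives 27700 nM, which sits close to the values of compound 1 and compound 2.

Compound 4 `CC(O)(CS(=O)(=O)c1cccc(C(F)(F)F)c1)C(=O)Nc1ccc(S(F)(F)(F)(F)F)cc1` has not yet been measured. It is related to compound 3 by 3-(trifluoromethyl)phenyl in place of 4-(trifluoromethyl)phenyl on a sulfonyl sulfur. Among the measured compounds shown here, this is the same kind of change as the one from compound 1 to compound 2, but not the same change: there the group sat on a sulfur whose other neighbours are a saturated chain carbon, whereas here it sits on a sulfonyl sulfur whose other neighbours are a saturated chain carbon. Since the earlier step was a 1.4-fold lower number from compound 1 to compound 2 (0.13 log units; within the scatter), a similarly small step is expected from compound 3 to compound 4, a 1.3-fold lower number from compound 3 to compound 4 (0.10 log units; within the scatter), because compound 3 starts from 27700 nM. The value expected for compound 4 in this assay is therefore 22000 nM, with a plausible range from 10000 nM to 45000 nM.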

Compound 4, half-maximal inhibitory concentration: 32000 nM
Compound 4: middle estimate off by 1.5-fold (0.16 log units), on the low side; the measured number falls inside the stated range.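

In this assay, swapping 4-(trifluoromethyl)phenyl for 3-(trifluoromethyl)phenyl on the sulfonyl sulfur gives a 1.2-fold higher number from compound 3 to compound 4 (0.06 log units; within the scatter), so this swap produces no change that can be told apart from repeat-to-repeat variation. The earlier step on the plain sulfur was just as small, and the two steps cannot be told apart either: the same change on two cores in this assay, a 1.4-fold lower number (0.13 log units; within the scatter) from compound 1 to compound 2 and a 1.2-fold higher number (0.06 log units; within the scatter) from compound 3 to compound 4, 1.6-fold (0.19 log units) apart, within the scatter of two such steps. This shows that on these two cores the swap leaves the read-out within the scatter, so the two results agree, but it does not show that the swap has a real effect of any size or direction that carries over, and two cores say nothing about how the swap would behave on a third.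

As far as these compounds go, it remains open whether a group other than trifluoromethyl on the phenyl ring, such as a chlorine, a nitrile or an amine, would give a step beyond the scatter in this assay. Also open is what the sulfur and the sulfonyl sulfur each contribute on their own, as the compounds shown offer no pair that differs in that one place.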